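The source may hold more compounds than are shown below. What is called first, only, known or untested is meant among the compounds shown, and "the series" means these compounds.

Working notes on the series. In a functional assay on T47D cells (Homo sapiens) for inhibition, read by CCK-8 assay, with a stated time of 72 h, tested at 1 uM (a higher number here means more inhibition of growth at the concentration tested, a lower number less inhibition of growth), compound 1 (`Cc1cccc(NC(=O)C2(C(=O)Nc3ccc(Nc4ncc5cc(C(=O)N(C)C)n(C6CCCC6)c5n4)cc3)CC2)c1`) gives 45.7%, and compound 2 (`CN(C)C(=O)c1cc2cnc(Nc3ccc(NC(=O)C4(C(=O)Nc5cccc(Br)c5)CC4)cc3)nc2n1C1CCCC1`) gives 29.1%, the lower of the two values. The next structure is compound 3 (`CN(C)C(=O)c1cc2cnc(Nc3ccc(NC(=O)C4(C(=O)Nc5ccc(O)cc5)CC4)cc3)nc2n1C1CCCC1`), which has not yet been measured. Its change from compound 2 is 4-hydroxyphenyl in place of 3-bromophenyl on an amide-type nitrogen.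

Among the compounds with values here, only one measured step bears on this change: a number 16.6 percentage points lower from compound 1 to compound 2 (beyond the scatter), with bromo in place of methyl on an aromatic carbon. Within the data shown here, that step is modest and alters the same aromatic ring, but it involves no hydroxyl group, so the series offers no direct precedent for this exchange. With only compound 1 at 45.7% as a comparison, a step of similar or smaller size is expected, with a slight lean upward and no firm direction. The estimate is a number 6.9 percentage points higher from compound 2 to compound 3 (within the scatter), which may not exceed the scatter. For compound 3, the expected value is 36%, within an estimated range of 16% to 56%.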

Compound 3, percent growth inhibition at one concentration: 91.5%
Compound 3: the middle estimate sits 55.5 percentage points below what was measured; measured number outside the range, above it.
By their numbers in this assay, from the lowest: compound 2; then compound 1; then compound 3.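

In this assay, the group on the amide-type nitrogen turns out to control the read-out far more strongly than the exchange of methyl for bromo had indicated: the series shows a number 62.4 percentage points higher from compound 2 to compound 3 (beyond the scatter) and a number 45.8 percentage points higher from compound 1 to compound 3 (beyond the scatter) when 4-hydroxyphenyl enters, compared with a number 16.6 percentage points lower from compound 1 to compound 2 (beyond the scatter) for the earlier change. The entering 4-hydroxyphenyl differs from 3-bromophenyl both in the substituent and in the number it carries in its name, and it brings 1 hydrogen-bond donor and 1 hydrogen-bond acceptor where the leaving group has none, so these compounds cannot separate the contribution of the hydroxyl from that of its placement on the ring. Nothing available here accounts for the size of this rise.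

Going by these compounds, it remains open whether 3-hydroxyphenyl would keep the high growth inhibition of compound 3, or whether plain phenyl would already recover part of it. It is equally unsettled whether 4-methoxyphenyl or 4-aminophenyl could take the place of 4-hydroxyphenyl, which would test whether the hydroxyl itself is needed.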